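Nitrophenyl exchange on the cyano-acrylamide arm: compound 4

The compounds below may be only part of what the source reports. "The series", "measured", "known", "first", "only" and "open" are said of these compounds alone.

Compound 1 `C/C(=N\NC(=O)/C(C#N)=C/c1ccccc1)c1c(O)c2ccc(O)cc2oc1=O`: 15800 nM
Compound 2 `COc1cc(/C=C(\C#N)C(=O)N/N=C(\C)c2c(O)c3ccc(O)cc3oc2=O)ccc1O`: 10500 nM
Compound 3 `C/C(=N\NC(=O)/C(C#N)=C/c1ccc([N+](=O)[O-])cc1)c1c(O)c2ccc(O)cc2oc1=O`: 8360 nM

All three values come from a functional assay on HeLa cells (Homo sapiens) for cytotoxicity, read by MTT assay, with a stated time of 24 h; a lower number here means a stronger inhibitor, a higher number a weaker inhibitor. Compound 2 has no distinct rank in this set, since its value lies within the scatter of the other two. The two steps that touch it are a 1.5-fold lower number from compound 1 to compound 2 (0.18 log units; within the scatter) and a 1.3-fold lower number from compound 2 to compound 3 (0.10 log units; within the scatter).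

The next compound for this assay is compound 4 `C/C(=N\NC(=O)/C(C#N)=C/c1ccccc1[N+](=O)[O-])c1c(O)c2ccc(O)cc2oc1=O`. The structural change is 2-nitrophenyl in place of 4-hydroxy-3-methoxyphenyl on a double-bonded chain carbon bound to a double-bonded chain carbon. Put simply, 2-nitrophenyl stands in place of 4-hydroxy-3-methoxyphenyl on a double-bonded chain carbon bound to a double-bonded chain carbon.

The closest measured precedent is a 1.3-fold lower number from compound 2 to compound 3 (0.10 log units; within the scatter), which removes the same group and brings in 4-nitrophenyl. Among the compounds with values here, also relevant is a 1.9-fold lower number from compound 1 to compound 3 (0.28 log units; within the scatter), the only measured step that adds nitro to the phenyl of compound 1. Both steps are small. Within the data shown here, no measured compound carries 2-nitrophenyl, so the data do not show what this particular group does. On that basis, no step beyond the scatter is expected, and the estimate is a 1.1-fold lower number from compound 2 to compound 4 (0.04 log units; within the scatter). For compound 4 the estimated value is 9500 nM, with an expected range of 4500 nM to 20000 nM.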

Compound 4, half-maximal inhibitory concentration: 10300 nM
Compound 4: the middle estimate sits 1.1-fold (0.04 log units) below what was measured; the measured number falls inside the stated range.
By their numbers in this assay, from the lowest: compounds 3, 4, 2 and 1 (each within the scatter of the next).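

In this assay, 2-nitrophenyl on a double-bonded chain carbon bound to a double-bonded chain carbon stays within the scatter of 4-hydroxy-3-methoxyphenyl (a 1.0-fold lower number from compound 2 to compound 4 (0.01 log units; within the scatter)) and of 4-nitrophenyl (a 1.2-fold higher number from compound 3 to compound 4 (0.09 log units; within the scatter)), so these data do not separate the two nitrophenyl groups. The step from the plain phenyl is also small (a 1.5-fold lower number from compound 1 to compound 4 (0.19 log units; within the scatter)), which means that all four aryl groups shown at this place lie within the scatter of one another. The hydrogen-bond donor counted on 4-hydroxy-3-methoxyphenyl is absent from 2-nitrophenyl, and the exchange still gives no step beyond the scatter, so that donor shows no measurable role among these compounds.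

Nothing available bears on why the four values lie so close together. It remains open whether an amine or a carboxylic acid on this phenyl, or a longer chain in place of it, would give a step beyond the scatter from compound 1, or whether any such group would simply join the four compounds already shown.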